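Swapping a formylphenyl sulfonyl for a pentafluorophenyl sulfonyl

The compounds below may be only part of what the source reports. "The series", "measured", "known", "first", "only" and "open" are said of these compounds alone.

Among the compounds with values here, compound 1 `COc1ccc(-c2cc(=O)c3c(OC)cc(OC)cc3n2C)cc1` is the only member of this small set with a number in a functional assay on SEM cells (Homo sapiens) for antiproliferative activity, with a stated time of 72 h; a lower number here means that less compound is needed, a higher number that more compound is needed for the effect: compound 1 gives 26000 nM. Compound 2 `COc1ccc(-c2cc(=O)c3c(OC)cc(OC)cc3n2Cc2ccccc2)cc1` returns in this assay only a limit, > 17300 nM. The step from compound 1 to compound 2, a step that the limit leaves unreadable from compound 1 to compound 2, cannot be sized because of the limit of > 17300 nM in this assay, at which 1 of the 3 values shown sits. For compound 3 `COc1ccc(-c2cc(=O)c3c(OC)cc(OC)cc3n2S(=O)(=O)c2ccc(C=O)cc2)cc1` no result is recorded in this assay: "not determined" (no result reported). Compound 4 `COc1ccc(-c2cc(=O)c3c(OC)cc(OC)cc3n2S(=O)(=O)c2c(F)c(F)c(F)c(F)c2F)cc1` differs from compound 3 by 2,3,4,5,6-pentafluorophenyl in place of 4-formylphenyl on a sulfonyl sulfur. Within the data shown here, no measured step touches this change, and compound 3 offers no starting value, so neither direction nor size of the move can be read from the data. Given that compound 1 gives 26000 nM, compound 4 is expected near 20000 nM, within 5000 nM to 60000 nM.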

Compound 4, half-maximal effective concentration: 3900 nM
Compound 4: the middle estimate sits 5.1-fold (0.71 log units) above what was measured; measured number below the stated range.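

No new step can be read between compound 3 and compound 4, as compound 3 carries no number in this assay. The compounds shown leave open how 2,3,4,5,6-pentafluorophenyl in place of 4-formylphenyl on a sulfonyl sulfur shifts the value in this assay.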